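The source may report more compounds than this note shows. Statements on the series, on what has been measured and on what is new or still open speak of the compounds shown alone.

Going by the values given here, compound 1 `Fc1ccc(-c2nn3ccc(NC4CCCC4)cc3c2-c2ccnc(NC3CCCC3)n2)cc1` gives in an ADME assay on Vero cells (Chlorocebus sabaeus) for cytotoxicity (on this read-out lower numbers stand for higher toxicity in this test and higher numbers for lower toxicity in this test), a value of 18000 nM and is the only compound here with an actual number. Compound 2 `Fc1ccc(-c2nn3ccc(N4CCCC4)cc3c2-c2ccnc(NC3CCCC3)n2)cc1` reaches only a limit of the test, > 40000 nM. Among the compounds with values here, the one measured step, an at least 2.2-fold higher number from compound 1 to compound 2 (0.34 log units; beyond the scatter), concerns a different part of the molecule. Compound 3 `CC(C)COc1ccc(-c2nn3ccc(NC4CCCC4)cc3c2-c2ccnc(NC3CCCC3)n2)cc1` differs from compound 1 by isobutoxy in place of fluoro on an aromatic carbon. Within the data shown here, no measured step touches this change, so no movement beyond the scatter is expected, and the estimate for compound 3 is a step of no change at the digits printed from compound 1 to compound 3 (within the scatter), giving an expected 18000 nM within 6000 nM to 50000 nM.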

Compound 3, half-maximal cytotoxic concentration: 27000 nM
Compound 3: the middle estimate sits 1.5-fold (0.18 log units) below what was measured; the measured number falls inside the stated range.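

Swapping fluoro for isobutoxy on the aromatic ring gives, in this assay, a 1.5-fold higher number from compound 1 to compound 3 (0.18 log units; within the scatter). This position, para to a large group, therefore takes a group of 5 heavy atoms in place of a single atom with no change in this test that stands out from the scatter. Any rise at this position can be read only up to a ceiling: the limit of > 40000 nM in this assay, at which 1 of the 3 values shown sits.

Going by these compounds, whether an amine, a carboxylic acid or a longer chain at this position would also leave the number unchanged stays open. So does how isobutoxy behaves alongside the pyrrolidin-1-yl group of compound 2.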